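The source may hold more compounds than are shown below. What is called first, only, known or untested is meant among the compounds shown, and "the series" means these compounds.

In a functional assay on U-87MG ATCC cells (Homo sapiens) for cytotoxicity, read by MTT assay, with a stated time of 72 h (on this read-out lower numbers stand for stronger inhibition and higher numbers for weaker inhibition), compound 3 `CN(C)CCn1cnnc1-c1cc(Oc2ccc(NC(=O)N/N=C/c3cccc(Br)c3)cc2F)ccn1` gives 830 nM, the lowest of the three numbers shown; compound 1 `COc1ccc(OC)c(/C=N/NC(=O)Nc2ccc(Oc3ccnc(-c4nncn4CCN(C)C)c3)c(F)c2)c1` gives 6400 nM and compound 2 `COc1ccc(/C=N/NC(=O)Nc2ccc(Oc3ccnc(-c4nncn4CCN(C)C)c3)c(F)c2)c(OC)c1` gives 12600 nM. The measured steps are a 7.7-fold lower number from compound 1 to compound 3 (0.89 log units; beyond the scatter) and a 15-fold lower number from compound 2 to compound 3 (1.18 log units; beyond the scatter), while a 2.0-fold higher number from compound 1 to compound 2 (0.29 log units; within the scatter) separates the two dimethoxy analogues. Compound 4 `COc1ccc(/C=N/NC(=O)Nc2ccc(Oc3ccnc(-c4nncn4CCN(C)C)c3)c(F)c2)cc1O` differs from compound 3 by 3-hydroxy-4-methoxyphenyl in place of 3-bromophenyl on a carbon with a double bond to nitrogen. Both steps that bear on this change ran from an oxygen-substituted phenyl to the bromophenyl and lowered the number, so the return to an oxygen-substituted phenyl in compound 4 is expected to raise the number in this assay by roughly a 6.0-fold higher number from compound 3 to compound 4 (0.78 log units; beyond the scatter). For the measured compounds named here, the single hydroxyl has no direct precedent here, so the range is kept wide. Compound 4 is therefore estimated at 5000 nM, between 1500 nM and 16000 nM.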

Compound 4, half-maximal inhibitory concentration: > 100000 nM
Compound 4 gave a limit, no number; the forecaster's own chance of this, stated with the estimate: 5%; middle value at least 20-fold (1.30 log units) away from the limit.
By their numbers in this assay, from the lowest: compound 3; then compounds 1 and 2 (each within the scatter of the next). At a limit, above all of these: compound 4.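

In this assay compound 4 gives a limit and not a number: the limit of > 100000 nM in this assay, at which 1 of the 4 values shown sits. At this position, on a carbon with a double bond to nitrogen, 3-hydroxy-4-methoxyphenyl gives an at least 120-fold higher number from compound 3 to compound 4 (2.08 log units; beyond the scatter), and it also separates from both dimethoxyphenyl groups, with an at least 7.9-fold higher number from compound 2 to compound 4 (0.89 log units; beyond the scatter) and an at least 15-fold higher number from compound 1 to compound 4 (1.19 log units; beyond the scatter). The oxygen-bearing phenyl groups therefore do not read alike, and the two dimethoxyphenyl compounds gave no warning of a shift this far.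

Still open, as far as these compounds go, is how a phenyl carrying only a hydroxyl, or one carrying an amine, would read in this assay. The compounds shown do not separate the hydroxyl itself from its pairing with the methoxy group.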